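Working notes: from compound 3 to compound 4

The source may hold more compounds than are shown below. What is called first, only, known or untested is meant among the compounds shown, and "the series" means these compounds.

Measured in a functional assay on A549 cells (Homo sapiens) for antiproliferative activity, read by MTT assay, with a stated time of 48 h; on this read-out lower numbers stand for stronger inhibition and higher numbers for weaker inhibition:
- compound 1 `O=C(CCCCCC(=O)Nc1ccc(O)c(C(=O)Nc2ccccc2)c1)NO`: 14600 nM
- compound 2 `O=C(CCCCCC(=O)Nc1ccc(O)c(C(=O)Nc2ccc(F)c(Cl)c2)c1)NO`: 21100 nM
- compound 3 `O=C(CCCCCC(=O)Nc1ccc(O)c(C(=O)Nc2ccc(Cl)c(Cl)c2)c1)NO`: 17800 nM

Not yet measured: compound 4 `O=C(CCCCCC(=O)Nc1ccc(O)c(C(=O)Nc2ccc(OCc3cccc(F)c3)c(Cl)c2)c1)NO`

Compound 3 gives 17800 nM and stands within the scatter of the other two compounds. The steps that reach it are a 1.2-fold higher number from compound 1 to compound 3 (0.09 log units; within the scatter) and a 1.2-fold lower number from compound 2 to compound 3 (0.07 log units; within the scatter), and the remaining one is a 1.4-fold higher number from compound 1 to compound 2 (0.16 log units; within the scatter). In this assay the three values therefore form one flat group.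

The next change is (3-fluorobenzyl)oxy in place of chloro on an aromatic carbon. In words, it is (3-fluorobenzyl)oxy in place of chloro on an aromatic carbon, ortho to a chloro group and para to a large group.

The closest measured precedent is the exchange at that same carbon, a 1.2-fold lower number from compound 2 to compound 3 (0.07 log units; within the scatter). The two steps from compound 1 also bear on it, though only as halogen changes. Among the measured compounds shown here, no measured step brings in a group of this size, so the data give no direct guide. The flat series suggests little movement, with a slight lean towards a lower number and a wide range in either direction.

The expected step is a 1.5-fold lower number from compound 3 to compound 4 (0.17 log units; within the scatter). For compound 4 the estimated value is 12000 nM, with an expected range of 4000 nM to 30000 nM.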

Compound 4, half-maximal inhibitory concentration: 12400 nM
The estimate for compound 4 lay 1.0-fold (0.01 log units) below the measured number, and the stated range covers the measured number.
By their numbers in this assay, from the lowest: compounds 4, 1, 3 and 2 (each within the scatter of the next).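

In this assay, the aromatic carbon ortho to a chloro group and para to a large group carries (3-fluorobenzyl)oxy, with 9 heavy atoms and a six-membered aromatic ring, in place of a single chloro atom, and the step stays inside the scatter: a 1.4-fold lower number from compound 3 to compound 4 (0.16 log units; within the scatter). The exchange for fluoro at that carbon reads the same way, a 1.7-fold lower number from compound 2 to compound 4 (0.23 log units; within the scatter), so the flat picture, earlier seen only across halogen changes, now extends to a group of much greater size. The data give no measurement that accounts for this flat result.

Still open, on these data alone, is whether any group at this carbon moves the number beyond the scatter, for instance an amine or a carboxylic acid in place of (3-fluorobenzyl)oxy. As far as these compounds go, it is also open whether the fluoro on the benzyl ring contributes anything, which a plain benzyloxy group would test, and whether a longer chain on the other side of the core would shift the values of this flat group.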